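Ester ring enlarged: from cyclopentyl to cyclohexyl

A few compounds are considered here, and "the series" means these few. Any claim that something is new, unique, unknown or untested is made for them only; others in the source may bear on it.

Of the compounds shown here, three sharing one core have been measured in an assay on membranes from CHO cells for displacement of a labelled ligand from adenosine receptor A1 (Homo sapiens), read by scintillation counting, with a stated time of 60 min, tested at 1 uM; on this read-out lower numbers stand for less inhibition and higher numbers for more inhibition at the one concentration tested (going by the name of the read-out). Among the measured compounds shown here, compound 1 `CC1=C(C(=O)OC2CCCCC2)C(c2ccco2)NC(=O)N1` gives 1%, and compound 2 `CC1=C(C(=O)OC2CCCCC2)C(c2ccoc2)NC(=O)N1` gives 15%; the only single-point step known is a number 14 percentage points higher from compound 1 to compound 2 (beyond the scatter). Compound 3 `CC1=C(C(=O)OC2CCCC2)C(c2ccsc2)NC(=O)N1` gives 5%, which lies within the scatter of both compound 1 and compound 2, so no order among them can be claimed.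

Compound 4 `CC1=C(C(=O)OC2CCCCC2)C(c2ccsc2)NC(=O)N1` differs from compound 3 in one place: cyclohexyl in place of cyclopentyl on an oxygen next to a carbonyl group. For the measured compounds named here, no measured pair shows this ester change, and the one known step concerns the furan and does not bear on it. The expectation is therefore a step of a number 1 percentage points higher from compound 3 to compound 4 (within the scatter) in this assay, lying within the scatter. Compound 4 is estimated at 6%, between -4% and 16%.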

Compound 4, a percentage reported as inhibition, at one concentration (the size of the read-out at that concentration, not a potency): 8%
Compound 4: middle estimate off by 2 percentage points, on the low side; the range from low to high includes it.
By their numbers in this assay, from the lowest: compounds 1, 3, 4 and 2 (each within the scatter of the next, the first and the last beyond it).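

In this assay, among the compounds shown here, the first look at this change on the oxygen shows that cyclohexyl in place of cyclopentyl, with thiophen-3-yl kept, gives no shift beyond the usual scatter (a number 3 percentage points higher from compound 3 to compound 4 (within the scatter)). With the cyclohexyl ester kept, thiophen-3-yl stands within the scatter of both furans (a number 7 percentage points lower from compound 2 to compound 4 (within the scatter); a number 7 percentage points higher from compound 1 to compound 4 (within the scatter)), although those two furans differ beyond it. No evidence is available to explain these numbers.

Still open, going by these compounds, is whether the ester change behaves the same with either furan, and whether a longer chain or an amine on the oxygen would move the number beyond the scatter.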